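From 3,4-Dichlorophenoxy to (4-Methoxyphenyl)sulfanyl on a Shared Core

The source may hold more compounds than are shown below. What is called first, only, known or untested is meant among the compounds shown, and "the series" means these compounds.

Of the compounds shown here, three built on a shared core have been measured so far. Compound 1 `Nc1cc(N)c2nc(-c3ccccc3)c(Oc3ccc(Cl)c(Cl)c3)nc2c1` carries a 3,4-dichlorophenoxy group and a phenyl group on that core. In a functional assay on K562 cells (Homo sapiens) for inhibition, read by sulforhodamine B assay, with a stated time of 48 h (a higher number here means that more compound is tolerated, a lower number that less compound is tolerated), compound 1 gives < 100000 nM, which is a limit of the assay and not a number. Compound 2 `CCOC(=O)[C@H](CCC(=O)O)NC(=O)c1ccc(Sc2nc3cc(N)cc(N)c3nc2-c2ccccc2)cc1` gives < 100000 nM in this assay, again only a limit. Compound 3 `COc1ccc(CNc2nc3cc(N)cc(N)c3nc2-c2ccccc2)cc1` gives < 100000 nM in this assay, also a limit. Compound 1 thus stands exactly where the other two stand: at the limit, with nothing to separate them, as the evidence shows (the limit of < 100000 nM in this assay, at which 3 of the 3 values shown sit).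

Compound 4 `COc1ccc(Sc2nc3cc(N)cc(N)c3nc2-c2ccccc2)cc1` is not yet measured and differs from compound 1 in one place: (4-methoxyphenyl)sulfanyl in place of 3,4-dichlorophenoxy on an aromatic carbon

Going by the values given here, every measured value in this assay is a limit (the limit of < 100000 nM in this assay, at which 3 of the 3 values shown sit), and no step between measured compounds can be sized, leaving no evidence for a shift in either direction beyond the scatter. Compound 4 is therefore expected to give 30000 nM in this assay, estimated to fall between 5000 nM and 100000 nM. The expected step that the limit leaves unreadable from compound 1 to compound 4 is none beyond the scatter, and the result is most likely to come back as a limit once more.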

Compound 4, concentration lethal to 50% of the cells: < 100000 nM
Compound 4: a limit, no number; the forecaster's own chance of this, stated with the estimate: 70%; the middle value does not contradict the limit.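

The result for compound 4 is again a limit and not a number, as it is for compound 1, so no step can be read between them: the limit of < 100000 nM in this assay, at which 4 of the 4 values shown sit.

The compounds shown leave open where any of them truly lies in this assay and whether (4-methoxyphenyl)sulfanyl in place of 3,4-dichlorophenoxy changes the value at all.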